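A few compounds are considered here, and "the series" means these few. Any claim that something is new, unique, unknown or untested is made for them only; others in the source may bear on it.

Measured so far in a functional assay on A375P cells (Homo sapiens) for antiproliferative activity, read by MTT assay, with a stated time of 48 h; a higher number here means a weaker inhibitor, a lower number a stronger inhibitor:
compound 1, `COc1ccc(C(=O)Nc2cccc(-c3ccnc4c(N)cccc34)c2)cc1OC`, gives 9500 nM
compound 2, `Nc1cccc2c(-c3cccc(NC(=O)c4ccc5c(c4)OCCO5)c3)ccnc12`, gives 860 nM
compound 3, `COc1ccc(C(=O)Nc2cccc(-c3ccnc4c(NC(C)=O)cccc34)c2)cc1OC`, gives 5300 nM

Compound 3 stands second highest of the three numbers in this assay; its nearest neighbour is compound 1, a gap within the scatter, and its furthest is compound 2, which lies beyond the scatter below it. The acetyl in place of hydrogen on a nitrogen on an aromatic ring gave a 1.8-fold lower number from compound 1 to compound 3 (0.25 log units; within the scatter). Compound 4, `CC(=O)Nc1cccc2c(-c3cccc(NC(=O)c4ccc(F)c(C(F)(F)F)c4)c3)ccnc12`, is compound 3 with 4-fluoro-3-(trifluoromethyl)phenyl in place of 3,4-dimethoxyphenyl on a carbonyl carbon. For the measured compounds named here, the only measured step at the carbonyl carbon is an 11-fold lower number from compound 1 to compound 2 (1.04 log units; beyond the scatter), which shows that exchanging the 3,4-dimethoxyphenyl at that place can move the number a long way, though the group entering in that step is not the one entering here. Some change in this assay is therefore expected, with the direction uncertain; the estimate is a modest step down, a 2.1-fold lower number from compound 3 to compound 4 (0.33 log units; beyond the scatter). Compound 4 is expected to give 2500 nM in this assay, within a range of 700 nM to 9000 nM.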

Compound 4, half-maximal inhibitory concentration: 6800 nM
Beside the measured number, compound 4's estimate is 2.7-fold (0.43 log units) below it, and the stated range covers the measured number.
By their numbers in this assay, from the lowest: compound 2; then compounds 3, 4 and 1 (each within the scatter of the next).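

In this assay, 4-fluoro-3-(trifluoromethyl)phenyl in place of 3,4-dimethoxyphenyl, on a carbonyl carbon whose other neighbour is an amide-type nitrogen, gives a 1.3-fold higher number from compound 3 to compound 4 (0.11 log units; within the scatter). An exchange at this place therefore need not move the number, in contrast with an 11-fold lower number from compound 1 to compound 2 (1.04 log units; beyond the scatter), so the large step seen earlier does not extend to every exchange of the 3,4-dimethoxyphenyl. No measured evidence accounts for the difference between these two steps.

Open, from the compounds shown here alone, is whether 2,3-dihydro-1,4-benzodioxin-6-yl gives a large step with acetyl on the aromatic nitrogen, and whether 4-fluoro-3-(trifluoromethyl)phenyl gives a small one with hydrogen there. Also open, going by these compounds, is how a nitrile in place of the trifluoromethyl, or a longer acyl chain in place of acetyl, would read.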